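Second methoxy on compound 1: expected effect

The compounds below may be only part of what the source reports. "The series", "measured", "known", "first", "only" and "open" are said of these compounds alone.

Measured in an assay on HepG2 cells for activation of nuclear factor erythroid 2-related factor 2 (Homo sapiens), read by a luciferase reporter, with a stated time of 5 h; a lower number here means that less compound is needed, a higher number that more compound is needed for the effect:
compound 1 `COc1ccc(/C=C/c2ccc(F)cc2)cc1` — 4200 nM
compound 2 `Cc1ccc(/C=C/c2ccc(F)cc2)cc1` — 1300 nM
compound 3 `Cc1ccc(/C=C/c2cccc(F)c2)cc1` — 800 nM

Compound 1 stands highest of the three numbers in this assay. Among the compounds with values here, the one single-point step among the measured compounds is a 3.2-fold lower number from compound 1 to compound 2 (0.51 log units; beyond the scatter), a modest gain on exchanging the methoxy for a methyl. Compound 3 differs from compound 2 in the position of the fluorine and from compound 1 in two places, so its value is read only beside the others: compound 3 gives 800 nM, while compound 1 gives 4200 nM.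

Compound 4 `COc1ccc(/C=C/c2ccc(F)cc2)cc1OC` is derived from compound 1 by methoxy in place of hydrogen on an aromatic carbon. Within the data shown here, none of the measured steps adds a substituent to the ring that already carries the methoxy; the step from compound 1 to compound 2 removes that methoxy rather than extends the substitution. The measured data therefore give no direct guide to this change. Among the measured compounds shown here, with no bearing step, the expectation is no step beyond the scatter, the estimate for compound 4 resting on the value of compound 1, 4200 nM. Compound 4 is thus expected to give about 4500 nM in this assay, within 1500 nM to 14000 nM, which corresponds to an expected step of a 1.1-fold higher number from compound 1 to compound 4 (0.03 log units; within the scatter).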

Compound 4, half-maximal effective concentration: 2600 nM
Estimate against measurement, compound 4: 1.7-fold (0.24 log units) above, within the range that was stated.
By their numbers in this assay, from the lowest: compounds 3, 2, 4 and 1 (each within the scatter of the next, the first and the last beyond it).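

In this assay, a methoxy in place of hydrogen on an aromatic carbon, ortho to a methoxy group and meta to a group of 9 heavy atoms, gives a 1.6-fold lower number from compound 1 to compound 4 (0.21 log units; within the scatter), so this ring carbon can carry the added group without a step beyond the scatter. The earlier compounds spoke only to replacing the existing methoxy, where methyl gives a 3.2-fold lower number from compound 1 to compound 2 (0.51 log units; beyond the scatter); they held no case of a further substituent on that ring, and compound 4 is the only such case shown. Nothing measured here bears on the reason for this outcome.

Open, on these data alone, is whether the same carbon also accepts other groups, such as an amine, a hydroxyl, a carboxylic acid or a longer chain such as ethoxy, as one substituent gives no measure of the range that fits there. Also open, as far as these compounds go, is how an added methoxy reads on the core of compound 2 or compound 3, whose ring carries methyl where compound 1 has methoxy.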